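Aryl-piperazine succinimide amides: electroshock activity notes

This account rests on a few compounds, and the source may have more. Where it says the series, first, only, none or still open, it means among the compounds named here.

Measured compounds:
compound 1 `COc1cccc(N2CCN(C(=O)C(C)N3C(=O)CCC3=O)CC2)c1`: 25%
compound 2 `CC(C(=O)N1CCN(c2ccc(Cl)cc2)CC1)N1C(=O)CCC1=O`: 50%
compound 3 `CC(C(=O)N1CCN(c2ccccc2F)CC1)N1C(=O)CCC1=O`: 75%

In a functional assay on the whole organism (strain Swiss) with Mus musculus as the target, in the maximal electroshock model, with a stated time of 0.25 h, at a dose of 100 mg/kg by the intraperitoneal route (on this read-out lower numbers stand for a weaker effect and higher numbers for a stronger effect at the one dose given), compound 3 gives 75% and stands highest of the three measured compounds. Its nearest neighbour is compound 2, as shown by a number 25 percentage points higher from compound 2 to compound 3 (beyond the scatter); the furthest is compound 1, as shown by a number 50 percentage points higher from compound 1 to compound 3 (beyond the scatter). The change from compound 2 onward is the one that matters here: a number 25 percentage points higher from compound 2 to compound 3 (beyond the scatter), where 2-fluorophenyl replaced 4-chlorophenyl.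

Compound 4 `CC(C(=O)N1CCN(c2ccc(F)cc2)CC1)N1C(=O)CCC1=O` differs from compound 3 by 4-fluorophenyl in place of 2-fluorophenyl on an amine nitrogen in a ring. Among the compounds with values here, no measured step compares two fluorophenyl groups directly; the only bearing is that compound 2 carries a 4-chlorophenyl and sits below compound 3, while compound 1 with 3-methoxyphenyl sits lowest. Compound 4 keeps the fluorine but moves it to the same ring position as the chlorine of compound 2, so a drop of the size seen in a number 25 percentage points higher from compound 2 to compound 3 (beyond the scatter) is a reasonable expectation, and the step to compound 4 is estimated as a number 25 percentage points lower from compound 3 to compound 4 (beyond the scatter). In this assay compound 4 is therefore expected at about 50%, within 25% to 75%.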

Compound 4, a percentage reported as activity, at one dose (the size of the read-out at that dose, not a potency): 75%
Compound 4: the middle estimate sits 25 percentage points below what was measured; low and high end bracket the measured number.
By their numbers in this assay, from the lowest: compound 1; then compound 2; then compounds 3 and 4 (each within the scatter of the next).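

In this assay the change from 2-fluorophenyl to 4-fluorophenyl on the amine nitrogen in the ring gives no change at the digits printed from compound 3 to compound 4 (within the scatter) and so does not separate the two fluorophenyl groups at this place. With the ring substituent changed in one place, fluoro in place of chloro on an aromatic carbon gives a number 25 percentage points higher from compound 2 to compound 4 (beyond the scatter) and 4-fluorophenyl in place of 3-methoxyphenyl gives a number 50 percentage points higher from compound 1 to compound 4 (beyond the scatter), so both fluorophenyl compounds stand clear of compound 1 and compound 2. Nothing available here explains these differences.

Open, from the compounds shown here alone, is whether a 2-chlorophenyl or a 4-methoxyphenyl at this place would read with the fluorophenyl pair or with compound 2 and compound 1. The read-out at one dose also leaves open whether compound 3 and compound 4 would stay level in the size of their effect at other doses.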